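This account rests on a few compounds, and the source may have more. Where it says the series, first, only, none or still open, it means among the compounds named here.

Compound 1 `CCn1c(C(=O)NCCN)ccc1C(CC)(CC)c1ccc(OCCC(O)(CC)CC)c(C)c1` serves as the reference point of the set. In a functional assay on MCF7 cells (Homo sapiens) for antiproliferative activity, read by MTT assay, with a stated time of 48 h (a higher number here means a weaker inhibitor, a lower number a stronger inhibitor), compound 1 gives 670 nM, the lowest of the two numbers in hand. Compound 3 `CCC(C)C(NC(=O)c1ccc(C(CC)(CC)c2ccc(OCCC(O)(CC)CC)c(C)c2)n1CC)C(=O)O` gives 11300 nM. Compound 2 `C#CC(C)OC(=O)c1ccc(C(CC)(CC)c2ccc(OCCC(O)(CC)CC)c(C)c2)n1CC` reaches only a limit of the assay, > 50000 nM. Compound 2 sits at the limit of > 50000 nM in this assay, at which 1 of the 3 values shown sits. Compound 4 `CCn1c(C(=O)N(C)CCO)ccc1C(CC)(CC)c1ccc(OCCC(O)(CC)CC)c(C)c1` is not yet measured; it differs from compound 1 by (2-hydroxyethyl)(methyl)amino in place of (2-aminoethyl)amino on a carbonyl carbon. The steps bearing on this are an at least 74-fold higher number from compound 1 to compound 2 (1.87 log units; beyond the scatter) and a 17-fold higher number from compound 1 to compound 3 (1.23 log units; beyond the scatter), each also removing the (2-aminoethyl)amino group, while an at least 4.4-fold lower number from compound 2 to compound 3 (0.64 log units; beyond the scatter) separates the two replacements. Both replacements at the carbonyl carbon gave large losses, so compound 4 is expected to weaken as well, by a 7.5-fold higher number from compound 1 to compound 4 (0.87 log units; beyond the scatter). The estimate for compound 4 is 5000 nM, with a range from 1500 nM to 20000 nM.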

Compound 4, half-maximal inhibitory concentration: 2870 nM
Compound 4: middle estimate off by 1.7-fold (0.24 log units), on the high side; the range from low to high includes it.
By their numbers in this assay, from the lowest: compound 1; then compound 4; then compound 3. At a limit, above all of these: compound 2.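

At the carbonyl carbon, (2-hydroxyethyl)(methyl)amino is far better tolerated in this assay than either earlier replacement, with a 3.9-fold lower number from compound 3 to compound 4 (0.60 log units; beyond the scatter) and an at least 17-fold lower number from compound 2 to compound 4 (1.24 log units; beyond the scatter). The (2-aminoethyl)amino group still gives the lowest number of the set, with a 4.3-fold higher number from compound 1 to compound 4 (0.63 log units; beyond the scatter). The second of those comparisons rests on a limit, that of compound 2: the limit of > 50000 nM in this assay, at which 1 of the 4 values shown sits.

The change swaps the terminal amine for a hydroxyl and adds a methyl on the amide nitrogen at once, and the two cannot be separated here. Open, from the compounds shown here alone, are (2-hydroxyethyl)amino and (2-aminoethyl)(methyl)amino, which would each isolate one change, and a longer chain ending in an amine.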